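Removing the Amide Group on Two Related Cores

The compounds below may be only part of what the source reports. "The series", "measured", "known", "first", "only" and "open" are said of these compounds alone.

Compound 1 `C=C(Br)C(=O)Nc1cccc(-c2cn3nc(Cc4ccccc4)sc3n2)c1` and compound 2 `Nc1cccc(-c2cn3nc(Cc4ccccc4)sc3n2)c1` share one core and differ only in hydrogen in place of (1-bromoethenyl)carbonyl on a nitrogen on an aromatic ring. In a functional assay on FM3A cells (Mus musculus) for inhibition, read by cell counting, with a stated time of 2 days (a higher number here means a weaker inhibitor, a lower number a stronger inhibitor), compound 1 gives 3000 nM, and compound 2 gives 4700 nM, so that the step is a 1.6-fold higher number from compound 1 to compound 2 (0.19 log units; within the scatter). Compound 3 `C=C(Br)C(=O)Nc1cccc(-c2cn3nc(-c4cccc(OC)c4)sc3n2)c1` is built on a different core, the difference from compound 1 being (3-methoxyphenyl in place of benzyl on an aromatic carbon); in this assay compound 3 gives 500 nM, a step of a 6.0-fold lower number from compound 1 to compound 3 (0.78 log units; beyond the scatter). Compound 4 `COc1cccc(-c2nn3cc(-c4cccc(N)c4)nc3s2)c1` has not yet been measured. It differs from compound 3 by hydrogen in place of (1-bromoethenyl)carbonyl on a nitrogen on an aromatic ring, the same change as that between compound 1 and compound 2, made at the same place. Since the step of a 1.6-fold higher number from compound 1 to compound 2 (0.19 log units; within the scatter) was small, a similarly small step is expected for compound 4 in this assay, namely a 1.6-fold higher number from compound 3 to compound 4 (0.20 log units; within the scatter). This expectation rests on a single measured pair, and the core of compound 3 is not the core on which that pair was measured, so the range is kept wide. Compound 4 is accordingly estimated at 800 nM, somewhere between 350 nM and 1900 nM.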

Compound 4, half-maximal inhibitory concentration: 29000 nM
The estimate for compound 4 lay 36-fold (1.56 log units) below the measured number; the measured number lies above the stated range.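

In this assay, putting hydrogen in place of (1-bromoethenyl)carbonyl on the nitrogen gives a 58-fold higher number from compound 3 to compound 4 (1.76 log units; beyond the scatter) on the core of compound 3. Among the compounds shown here, the size of this step therefore did not carry over from one core to the other, so a small step on one core was no guide to the step on the other: the same change on two cores in this assay, a 1.6-fold higher number (0.19 log units; within the scatter) from compound 1 to compound 2 and a 58-fold higher number (1.76 log units; beyond the scatter) from compound 3 to compound 4, 37-fold (1.57 log units) apart, beyond the scatter of two such steps. For the compounds shown here, this shows that the effect of the change depends on the core, at least for these two cores, which differ by 3-methoxyphenyl in place of benzyl, but with only one pair on each core it does not show why the steps differ or what the change would do on any third core.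

The compounds shown leave open whether a simpler group on that nitrogen, such as acetyl, would keep the number close to that of compound 3 or move it towards that of compound 4. They also leave open how a step would look with other groups in place of the 3-methoxyphenyl, such as an unsubstituted phenyl.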